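Sulfo in place of carboxy on the phenyl of compound 2

The source may report more compounds than this note shows. Statements on the series, on what has been measured and on what is new or still open speak of the compounds shown alone.

Compound 1, `Cc1ccc(-n2[nH]c(C)c(/N=N/c3c(O)cc(S(=O)(=O)O)c4ccccc34)c2=O)cc1C`, gives 100% in an assay on BaF3 cells with thrombopoietin receptor (Homo sapiens) as the target, read by a luciferase reporter; a lower number here means a smaller maximal response, a higher number a larger maximal response.
Compound 2, `Cc1[nH]n(-c2ccc(C(=O)O)cc2)c(=O)c1/N=N/c1c(O)cc(S(=O)(=O)O)c2ccccc12`, is reported in this assay only as the limit < 5%.

Compound 2 thus stands at the floor of what this assay can report; its value is a limit rather than a number, namely (the limit of < 5% in this assay, at which 1 of the 2 values shown sits). Compound 3, `Cc1[nH]n(-c2ccc(S(=O)(=O)O)cc2)c(=O)c1/N=N/c1c(O)cc(S(=O)(=O)O)c2ccccc12`, takes one further step from compound 2: sulfo in place of carboxy on an aromatic carbon. Among the measured compounds shown here, the only measured step, a number at least 95 percentage points lower from compound 1 to compound 2 (beyond the scatter), concerns a different exchange on the same aromatic nitrogen. For the measured compounds named here, it shows that the group on this phenyl can shift the maximal response strongly in this assay, yet no measured pair tests sulfo against carboxy, so the direction of this change is not covered by the data. With compound 2 already at the limit, the change is expected to be small, a number no lower from compound 2 to compound 3 (the limit leaves the size open). Compound 3 is expected to give about 5%, within 0% to 25%, most likely again reported as a limit.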

Compound 3, largest response reached (reported as efficacy), in percent of the reference or control that the assay uses: < 5%
Compound 3 ended at the assay's limit; the forecaster's own chance of this, stated with the estimate: 70%; the middle value sits exactly at the limit.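

In this assay there is a number at least 95 percentage points lower from compound 1 to compound 3 (beyond the scatter), so the loss of response seen with 4-carboxyphenyl on this aromatic nitrogen is not confined to that one group. A second replacement for 3,4-dimethylphenyl, this time carrying sulfo instead of carboxy, ends at the same floor. Sulfo and carboxy cannot be ranked against each other here, because the step from compound 2 to compound 3 joins two limits and cannot be read: the limit of < 5% in this assay, at which 2 of the 3 values shown sit.

As far as these compounds go, what stays open is whether any group on this phenyl other than the two methyl groups can keep the response, for instance an amine or a methyl ester in the place of the sulfo group. From the compounds shown here alone, it is also open whether a single methyl group would be enough, and how much response lies between these extremes.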